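The compounds below may be only part of what the source reports. "The series", "measured", "known", "first", "only" and "open" are said of these compounds alone.

Compound 1 `C=CCn1c(=O)/c(=C\c2ccccc2F)[nH]c(=O)/c1=C\c1ccccc1OC`: 18900 nM
Compound 2 `COc1ccccc1/C=c1/[nH]c(=O)/c(=C\c2cccc(Cl)c2Cl)[nH]c1=O`: "not active" (no number reported)

In a functional assay on BGC-823 cells (Homo sapiens) for cytotoxicity, read by CCK-8 assay, with a stated time of 72 h (a higher number here means a weaker inhibitor, a lower number a stronger inhibitor), compound 1 gives 18900 nM, the only number shown, so it is the one reference point. Going by the values given here, compound 2 is recorded in this assay as "not active" (no number reported), without a number, and no pair of measured compounds differing in a single place is available to size a step. Compound 3 `C=CCn1c(=O)/c(=C\c2cc(Br)ccc2F)[nH]c(=O)/c1=C\c1ccccc1OC` differs from compound 1 by bromo in place of hydrogen on an aromatic carbon. Among the compounds with values here, with no comparable step measured, only a small change is expected, likely within the usual scatter. Compound 3 is estimated at 13000 nM, expected between 4500 nM and 40000 nM. This expectation corresponds to a step of a 1.5-fold lower number from compound 1 to compound 3 (0.16 log units; within the scatter).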

Compound 3, half-maximal inhibitory concentration: "not active" (no number reported)
Compound 3: no number reported; no gap can be computed for the estimate.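

Going by these compounds alone, compound 3 is recorded as "not active" in this assay, without a number, and no step from compound 1 to compound 3 can be read. Nothing else shown bears on this result. On these data alone, how far bromo in place of hydrogen shifts the value of compound 1 stays open.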